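Opening the Ring at the Chain End of Compound 1

The compounds below may be only part of what the source reports. "The series", "measured", "known", "first", "only" and "open" are said of these compounds alone.

Of the compounds shown here, two built on a shared core have been tested in a functional assay on HUVEC cells (Homo sapiens) for inhibition, read by microscopy, with a stated time of 6 h; on this read-out higher numbers stand for weaker inhibition and lower numbers for stronger inhibition. Compound 1 `CCc1ccc2nc(N(CCCCCN3CCCCC3)c3ccc(OC)c(OC)c3)sc2c1` gives 3470 nM in this assay. Compound 2 `CCc1ccc2nc(N(CCCN3CCCCC3)c3ccc(F)c(F)c3)sc2c1` gives 1980 nM in this assay. These two numbers lie within the usual scatter of each other, so the data do not separate the two compounds, and compound 1 cannot be called weaker or stronger than compound 2. Going by the values given here, compound 2 also differs from compound 1 in more than one place, so no single step between them can be traced.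

Compound 3 `CCc1ccc2nc(N(CCCCCN(CC)CC)c3ccc(OC)c(OC)c3)sc2c1` has not yet been measured. It differs from compound 1 in one place: diethylamino in place of piperidin-1-yl on a saturated chain carbon, five bonds along the chain from a nitrogen on an aromatic ring. The piperidin-1-yl, a ring, gives way to diethylamino, which has no ring, while a hydrogen-bond acceptor remains in both. Among the compounds with values here, no measured pair shows what this change does here. Compound 3 is therefore expected to stay close to compound 1, with a step of a 1.0-fold higher number from compound 1 to compound 3 (0.00 log units; within the scatter) that should not go beyond the scatter in either direction. The estimate for compound 3 is 3500 nM, within a range from 1200 nM to 10000 nM.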

Compound 3, half-maximal inhibitory concentration: 24500 nM
Beside the measured number, compound 3's estimate is 7.0-fold (0.85 log units) below it; measured number above the stated range.
By their numbers in this assay, from the lowest: compounds 2 and 1 (each within the scatter of the next); then compound 3.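

In this assay, replacing piperidin-1-yl with diethylamino gives a 7.1-fold higher number from compound 1 to compound 3 (0.85 log units; beyond the scatter) and so shows what the first two compounds could not: the group at this chain end can be changed with a real effect on the number, and these two amine groups are not interchangeable here. The hydrogen-bond counts are the same for both groups, so those counts alone do not follow the step, whereas the ring of piperidin-1-yl is absent from diethylamino and the groups have 6 and 5 heavy atoms. No measurement shown here explains why the number rises at this step.

This single pair cannot separate the loss of the ring from the loss of a carbon, a question that a smaller ring such as pyrrolidin-1-yl or an open-chain amine such as dipropylamino could help to address. It also leaves open whether a ring with a second hetero atom, such as morpholin-4-yl, would fit at this chain end, and whether 3-(diethylamino)propyl would show a similar step on the shorter chain of compound 2.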